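Replacing methylsulfamoyl with fluoro on compound 2

The source may hold more compounds than are shown below. What is called first, only, known or untested is meant among the compounds shown, and "the series" means these compounds.

Compound 1 `CC(C)n1ncc2c(C(=O)Nc3ncccn3)cc(-c3cccs3)nc21`: 75000 nM
Compound 2 `CNS(=O)(=O)c1cccc(NC(=O)c2cc(-c3cccs3)nc3c2cnn3C(C)C)c1`: 25000 nM

The measurement here is an ADME assay on LLC-MK2 cells (Macaca mulatta) for cytotoxicity, read by spectrophotometry and crystal violet staining, with a stated time of 4 days; a lower number here means that less compound is tolerated, a higher number that more compound is tolerated. Compound 2, at 25000 nM, has the lower of the two numbers, so less of it is tolerated than of compound 1, and the gap between them lies beyond the scatter.

The next molecule, compound 3 `CC(C)n1ncc2c(C(=O)Nc3cccc(F)c3)cc(-c3cccs3)nc21`, has not been measured. It differs from compound 2 in one place: fluoro in place of methylsulfamoyl on an aromatic carbon.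

Within the data shown here, no two measured compounds differ in just one place, so nothing shows directly what such a swap does in this assay. Among the measured compounds shown here, the only guides are compound 2 at 25000 nM and compound 1 at 75000 nM, and neither points to a large move. The expected change is a 1.2-fold higher number from compound 2 to compound 3 (0.08 log units; within the scatter), a slight rise at most and none beyond the scatter. For compound 3 the estimated value is 30000 nM, with an expected range of 10000 nM to 90000 nM.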

Compound 3, half-maximal cytotoxic concentration: > 200000 nM
Compound 3: only a limit was reported; the forecaster's own chance of this, stated with the estimate: 10%; at least 6.6-fold (0.82 log units) between middle value and limit.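

Swapping methylsulfamoyl for fluoro on the six-membered aromatic ring of carbon only gives an at least 8.0-fold higher number from compound 2 to compound 3 (0.90 log units; beyond the scatter), so in this assay a change at this single position is enough to move the result beyond the scatter, and the move is towards more compound being tolerated. The group on the amide-type nitrogen matters as well: 3-fluorophenyl in place of pyrimidin-2-yl gives an at least 2.6-fold higher number from compound 1 to compound 3 (0.42 log units; beyond the scatter), which shows that this fluorinated ring is tolerated better than either earlier amide group. Compound 3 reads > 200000 nM, which is a limit and not a number, so both steps give only a smallest size and their full size stays unknown: the limit of > 200000 nM in this assay, at which 1 of the 3 values shown sits.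

The compounds shown do not separate losing methylsulfamoyl from gaining fluoro, as none carries plain hydrogen at this place on the ring. They also leave open where a group such as an amine or a carboxylic acid would fall at this position, and whether any change here would bring the reading back under the limit.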